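The compounds below may be only part of what the source reports. "The series", "measured", "known", "first", "only" and "open" are said of these compounds alone.

Measured compounds:
compound 1 `COc1ccccc1/C=c1/[nH]c(=O)/c(=C\c2cccc(Cl)c2Cl)[nH]c1=O` — "not active" (no number reported) in a functional assay on BGC-823 cells (Homo sapiens) for cytotoxicity, read by CCK-8 assay, with a stated time of 72 h; on this read-out lower numbers stand for stronger inhibition and higher numbers for weaker inhibition
compound 2 `C=CCn1c(=O)/c(=C\c2cccc(F)c2)[nH]c(=O)/c1=C\c1ccccc1OC` — 5600 nM
compound 3 `C=CCn1c(=O)/c(=C\c2ccccc2Cl)[nH]c(=O)/c1=C\c1ccccc1OC` — 4600 nM

Compound 2 gives the highest of the two numbers, with compound 3 nearest; the step of a 1.2-fold lower number from compound 2 to compound 3 (0.09 log units; within the scatter) is within the scatter. Going by the values given here, compound 1 differs from compound 2 in more than one place and no step to it is drawn.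

Compound 4 `C=CCn1c(=O)/c(=C\c2ccccc2OC)[nH]c(=O)/c1=C\c1ccccc1OC` is not yet measured. It differs from compound 2 by 2-methoxyphenyl in place of 3-fluorophenyl on a double-bonded chain carbon bound to an aromatic carbon. Among the compounds with values here, the only measured step at this place is a 1.2-fold lower number from compound 2 to compound 3 (0.09 log units; within the scatter), which did not move the number beyond the scatter. On that basis no step beyond the scatter is expected for a 1.1-fold lower number from compound 2 to compound 4 (0.05 log units; within the scatter). Compound 4 is therefore estimated at 5000 nM, in the range 2000 nM to 15000 nM.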

Compound 4, half-maximal inhibitory concentration: 13400 nM
The estimate for compound 4 lay 2.7-fold (0.43 log units) below the measured number; measured number inside the range.
By their numbers in this assay, from the lowest: compounds 3 and 2 (each within the scatter of the next); then compound 4.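

At this place the aryl group is no longer neutral in this assay: 2-methoxyphenyl in place of 3-fluorophenyl weakens inhibition beyond the scatter (a 2.4-fold higher number from compound 2 to compound 4 (0.38 log units; beyond the scatter)). Methoxy in place of chloro does the same (a 2.9-fold higher number from compound 3 to compound 4 (0.46 log units; beyond the scatter)), so the number at this place does respond to the group, which the step between the two halogen-bearing compounds did not show. No available data explain this shift.

Still open, on these data alone, is whether an amine or a carboxylic acid on this phenyl ring would move the number, and in which direction.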